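Cyclobutane stereoisomer: working notes on compound 3

The source may report more compounds than this note shows. Statements on the series, on what has been measured and on what is new or still open speak of the compounds shown alone.

Compound 1, `O=C(c1ccc(O)cc1O)[C@@H]1[C@@H](C(=O)c2ccc(O)cc2O)[C@H](c2ccccc2)[C@@H]1c1ccccc1`, was tested in a functional assay on PC-3 cells (Homo sapiens) for cytotoxicity, read by MTT assay, with a stated time of 48 h, tested at 5 uM (a higher number here means a stronger effect of the compound at the concentration tested, a lower number a weaker effect), where compound 1 gives 29%. Going by the values given here, the only other measured member of the series is compound 2, `O=C(c1ccc(O)cc1O)[C@H]1Cc2ccccc2[C@@H](C(=O)c2ccc(O)cc2O)[C@H]1c1ccccc1`, which in this assay gives 46.1%. Compound 1 thus stands at the lower of the two measured numbers, and the gap to compound 2 lies beyond the usual scatter of repeated measurements. Compound 2 carries a different core, so its value says nothing direct about how configuration at the shared core of compound 1 matters.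

The next compound, compound 3, `O=C(c1ccc(O)cc1O)[C@H]1[C@H](C(=O)c2ccc(O)cc2O)[C@@H](c2ccccc2)[C@@H]1c1ccccc1`, has not yet been measured in this assay. How compound 3 differs from compound 1: the two compounds have the same atoms and bonds and differ only in configuration as drawn: 3 of 4 stereo elements differ; a stereocentre at a saturated ring carbon is drawn S in compound 1 and R in compound 3; a stereocentre at a saturated ring carbon is drawn S in compound 1 and R in compound 3; a stereocentre at a saturated ring carbon is drawn R in compound 1 and S in compound 3. Among the compounds with values here, no step between two measured compounds of this kind exists, so the size and direction of a pure change in configuration is unknown here. In the absence of such a step, compound 3 is expected to stay close to compound 1, with the step of a number 3 percentage points higher from compound 1 to compound 3 (within the scatter) estimated as none beyond the scatter, though a shift in either direction cannot be excluded. For compound 3 the estimate in this assay is 32%, with a range from 12% to 55%.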

Compound 3, a percentage reported as activity, at one concentration (the size of the read-out at that concentration, not a potency): 49.7%
The estimate for compound 3 lay 17.7 percentage points below the measured number; measured number inside the range.
By their numbers in this assay, from the lowest: compound 1; then compounds 2 and 3 (each within the scatter of the next).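

The series now holds its first reading of configuration alone at the shared core, and in this assay the step is a number 20.7 percentage points higher from compound 1 to compound 3 (beyond the scatter). The earlier compounds shown here could not show this, since compound 2 carries a different core and its value offers no reading of configuration. Configuration on this core therefore has to count as a variable in its own right, and the step can be tied to the drawn arrangement alone because no atom or bond changes: the fact that compounds 1 and 3 differ only in the configuration as drawn.

Three of the four stereo elements change together, so the compounds shown leave open whether one stereocentre carries the step or whether it needs all three, and they say nothing about the direction or size of the step for any other arrangement on this core. Also open, from the compounds shown here alone, is whether the same difference between the two configurations would hold with an amine or a carboxylic acid in place of a phenyl group, and whether it would extend beyond a read-out taken at a single concentration, which gives the size of an effect and not a potency.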